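The source may hold more compounds than are shown below. What is called first, only, known or untested is meant among the compounds shown, and "the series" means these compounds.

Of the compounds shown here, three have so far been tested in an assay on cells for displacement of a labelled ligand from adenosine receptor A1 (Homo sapiens), read by radioligand binding, with a stated time of 60 min, tested at 1 uM; on this read-out higher numbers stand for more inhibition at the one concentration tested (going by the name of the read-out) and lower numbers for less inhibition. Compound 1, `CC(C)OC(=O)C1=C(C(F)(F)F)NC(=O)NC1c1ccco1`, gives 11% in this assay. Compound 2, `CC1=C(C(=O)OC(C(F)(F)F)C(F)(F)F)C(c2cccs2)NC(=O)N1`, gives 9%, and compound 3, `CC1=C(C(=O)OC(C(F)(F)F)C(F)(F)F)C(c2ccco2)NC(=O)N1`, gives 6%. All three numbers lie within the usual scatter of one another, so none of the three numbers can be called higher or lower than the others.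

Compounds 2 and 3 share a core and differ in one place: thiophen-2-yl in place of furan-2-yl on a saturated ring carbon. This exchange made a step of a number 3 percentage points higher from compound 3 to compound 2 (within the scatter). How the core of compound 1 differs from the core of compound 3 is not broken down here.

Compound 4, `CC(C)OC(=O)C1=C(C(F)(F)F)NC(=O)NC1c1cccs1`, has not yet been measured in this assay. It differs from compound 1 in one place: thiophen-2-yl in place of furan-2-yl on a saturated ring carbon. Within the data shown here, this is the same kind of change as the one from compound 3 to compound 2, but not the same change, since the surroundings differ: in compound 1 the saturated ring carbon sits next to the ring atom that bears an isopropoxycarbonyl group and two ring bonds from the ring atom that bears a trifluoromethyl group, whereas in compound 3 it sits next to the ring atom that bears a large group and two ring bonds from the ring atom that bears a methyl group.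

A step of a number 3 percentage points higher from compound 1 to compound 4 (within the scatter) is expected, because the earlier step of a number 3 percentage points higher from compound 3 to compound 2 (within the scatter) stayed within the scatter. Compound 4 is therefore estimated to give 14% in this assay, with a likely range from 4% to 24%.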

Compound 4, a percentage reported as inhibition, at one concentration (the size of the read-out at that concentration, not a potency): 8%
For compound 4 the middle estimate is 6 percentage points above the measured one, within the range that was stated.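

On the core of compound 1, putting thiophen-2-yl in place of furan-2-yl on the saturated ring carbon gives a step of a number 3 percentage points lower from compound 1 to compound 4 (within the scatter) in this assay. Set beside the same exchange on the other core, the result gives no sign that the core alters what this change does, as the two steps cannot be told apart: the same change on two cores in this assay, a number 3 percentage points higher (within the scatter) from compound 3 to compound 2 and a number 3 percentage points lower (within the scatter) from compound 1 to compound 4, 6 percentage points apart, within the scatter of two such steps. This does not prove that the change behaves identically on both cores or has no effect at all, as a small real effect could stay hidden within the scatter, and these two pairs say nothing about a core on which the numbers are much higher.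

The compounds shown carry only furan-2-yl or thiophen-2-yl on the saturated ring carbon, which leaves open what a phenyl ring or a ring bearing an amine would do at that place. Also open, on these data alone, is what a carboxylic acid or a longer chain would do in place of the isopropoxycarbonyl group, and whether any such exchange would give a step beyond the scatter in this assay.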